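Swapping Iodo for Nitro on an Inactive Amide

A few compounds are considered here, and "the series" means these few. Any claim that something is new, unique, unknown or untested is made for them only; others in the source may bear on it.

Measured so far:
compound 1, `CC(C)n1ncc2c(C(=O)NC3CCCC3)cccc21` — > 40000 nM
compound 2, `CC(C)n1ncc2c(C(=O)NCc3cn(-c4ccc(I)cc4)nn3)cccc21` — > 40000 nM

Both compounds share the same core and differ only in the group attached to the amide nitrogen. In a functional assay on MCF7 cells (Homo sapiens) for inhibition, read by MTT assay, with a stated time of 72 h (a lower number here means a stronger inhibitor, a higher number a weaker inhibitor), compound 1 gives > 40000 nM, which is a limit of the assay rather than a number. In this assay compound 2 likewise gives > 40000 nM, again a limit and not a number. Compound 2 therefore stands nowhere distinct on the numbers shown: both values sit at the limit of > 40000 nM in this assay, at which 2 of the 2 values shown sit, so no ordering between compound 1 and compound 2 can be read from them.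

Compound 3, `CC(C)n1ncc2c(C(=O)NCc3cn(-c4ccc([N+](=O)[O-])cc4)nn3)cccc21`, has not been measured. It differs from compound 2 by nitro in place of iodo on an aromatic carbon. Among the measured compounds shown here, no measured step exists to calibrate what this change does. With both measured compounds at the limit, the expectation for this assay is no step beyond the scatter, and the step from compound 2 to compound 3 is estimated as a step that the limit leaves unreadable from compound 2 to compound 3. Compound 3 is expected to give about 45000 nM, in the range 15000 nM to 150000 nM, most likely again reported only as a limit.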

Compound 3, half-maximal inhibitory concentration: > 40000 nM
Compound 3 ended at the assay's limit; the forecaster's own chance of this, stated with the estimate: 75%; the middle value does not contradict the limit.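

In this assay compound 3 gives > 40000 nM, a limit and not a number. No step can be read from compound 2 to compound 3, so nitro in place of iodo on an aromatic carbon has no readable size: the limit of > 40000 nM in this assay, at which 3 of the 3 values shown sit. The compounds shown leave open how these three rank against one another and what change to this shared structure would give a measurable number.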